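A few compounds are considered here, and "the series" means these few. Any claim that something is new, unique, unknown or untested is made for them only; others in the source may bear on it.

Compound 1, `CN1CCN(c2nc(Cl)nc3c2ncn3Cc2ccc(C(=O)Nc3ccccc3N)cc2)CC1`, is the reference point of this set. Among the measured compounds shown here, in a functional assay on HCT-116 cells (Homo sapiens) for antiproliferative activity, read by CCK-8 assay, with a stated time of 72 h, tested at 8 uM (on this read-out lower numbers stand for a weaker effect and higher numbers for a stronger effect at the one concentration tested), compound 1 gives 72.8%, the highest of the three numbers so far measured. Compound 2, `CCCCn1cnc2c(Nc3ccccc3)nc(NCOCc3ccc(/C=C/C(=O)Nc4ccccc4N)cc3)nc21`, stands nearest to it, with 51.9% in this assay, a gap that lies beyond the usual scatter. Compound 3, `Cc1ccc(Nc2nc(Cl)nc3c2ncn3Cc2ccc(/C=C/C(=O)Nc3ccccc3N)cc2)cc1`, lies furthest away, giving 15% in this assay, again well beyond the scatter. Compound 1 is therefore the strongest of the three on this read-out.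

The next compound, compound 4, `Nc1ccccc1NC(=O)c1ccc(Cn2cnc3c(NCc4ccccc4)nc(Cl)nc32)cc1`, differs from compound 1 in a single place: benzylamino in place of 4-methylpiperazin-1-yl on an aromatic carbon. For the measured compounds named here, no pair of measured compounds with exactly this exchange exists here, so the size of the step can only be guessed. Compound 3, which carries an arylamino group at the same ring position beside the chloro group, gives 15% in this assay, which points downward. Compound 4 is expected to reach about 50%, within a range of 28% to 72%, an expected step of a number 22.8 percentage points lower from compound 1 to compound 4 (beyond the scatter) beyond the scatter.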

Compound 4, a percentage reported as inhibition, at one concentration (the size of the read-out at that concentration, not a potency): 78.4%
Compound 4: the middle estimate sits 28.4 percentage points below what was measured, and the stated range ends below it.
By their numbers in this assay, from the lowest: compound 3; then compound 2; then compounds 1 and 4 (each within the scatter of the next).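

In this assay, benzylamino in place of 4-methylpiperazin-1-yl gives a number 5.6 percentage points higher from compound 1 to compound 4 (within the scatter). Among the compounds shown here, this is the first direct reading at this aromatic carbon, and it shows that a six-membered non-aromatic ring with two hetero atoms and a group carrying a six-membered aromatic ring of carbon only cannot be told apart here on this read-out. No measurement shown accounts for this result.

The compounds shown leave open how morpholin-4-yl, a simple anilino group or the longer phenethylamino chain would read at this same carbon. They also leave open whether compound 1 and compound 4 would still not be told apart at other concentrations, since a reading at one concentration is not a potency.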